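A few compounds are considered here, and "the series" means these few. Any claim that something is new, unique, unknown or untested is made for them only; others in the source may bear on it.

In a functional assay on MCF7 cells (Homo sapiens) for cytotoxicity, read by MTT assay, with a stated time of 72 h (a higher number here means a weaker inhibitor, a lower number a stronger inhibitor), compound 3 `O=C1C(=Cc2ccc(Cl)cc2Cl)C(=O)N(c2ccc(Cl)cc2)N1c1ccc(Cl)cc1` gives only a limit, > 128000 nM. Compound 1 `CN(C)c1ccc(C=C2C(=O)N(c3ccc(Cl)cc3)N(c3ccc(Cl)cc3)C2=O)cc1` likewise gives only a limit, > 128000 nM. Compound 2 `COc1cccc(C=C2C(=O)N(c3ccc(Cl)cc3)N(c3ccc(Cl)cc3)C2=O)c1` alone gives a number, 18100 nM.

Compound 4 `O=C1C(=C/C=C/c2ccccc2)C(=O)N(c2ccc(Cl)cc2)N1c1ccc(Cl)cc1` carries 2-phenylethenyl in place of 2,4-dichlorophenyl on a double-bonded chain carbon bound to a double-bonded ring carbon.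

Three measured steps change this same place: an at least 7.0-fold lower number from compound 1 to compound 2 (0.84 log units; beyond the scatter), an at least 7.0-fold higher number from compound 2 to compound 3 (0.84 log units; beyond the scatter) and a step that the two limits leave unreadable from compound 1 to compound 3. The first two lie beyond the scatter, and the third cannot be read. Swaps here can therefore move the number, so a modest fall is expected, although another limit remains possible. The expected change is an at least 3.2-fold lower number from compound 3 to compound 4 (0.50 log units; beyond the scatter). For compound 4, the estimate is 40000 nM, with an expected range of 12000 nM to 128000 nM.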

Compound 4, half-maximal inhibitory concentration: 9400 nM
For compound 4 the middle estimate is 4.3-fold (0.63 log units) above the measured one; measured number outside the range, below it.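

At the place on a double-bonded chain carbon bound to a double-bonded ring carbon, 2-phenylethenyl gives a large gain in this assay: an at least 13-fold lower number from compound 3 to compound 4 (1.13 log units; beyond the scatter) and an at least 13-fold lower number from compound 1 to compound 4 (1.13 log units; beyond the scatter). Against 3-methoxyphenyl the swap gives a 1.9-fold lower number from compound 2 to compound 4 (0.28 log units; within the scatter), so a readable number at this place is not tied to 3-methoxyphenyl. The two large steps give only minimum sizes, because compound 1 and compound 3 each rest on a limit of the assay: the limit of > 128000 nM in this assay, at which 2 of the 4 values shown sit.

Still open, from the compounds shown here alone, is whether an amine or a carboxylic acid on the phenyl ring of 2-phenylethenyl, or a longer chain with further double bonds, would move the number beyond the scatter.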